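Compound 3: a Far Larger Substituent on the Shared Core

The source may report more compounds than this note shows. Statements on the series, on what has been measured and on what is new or still open speak of the compounds shown alone.

Compound 2 `C[Si](C)(C)c1cn(C[C@H](O)[C@H]2OC(=O)C(OCc3ccccc3)=C2OCc2ccccc2)nn1` gives 19200 nM in a functional assay on A549 cells (Homo sapiens) for antiproliferative activity, read by MTT assay, with a stated time of 72 h (a lower number here means a stronger inhibitor, a higher number a weaker inhibitor), the lowest of the two numbers at hand. Its nearest neighbour is compound 1 `CC(C)(C)c1cn(C[C@H](O)[C@H]2OC(=O)C(OCc3ccccc3)=C2OCc2ccccc2)nn1`, which in this assay gives 34000 nM, and the step of a 1.8-fold lower number from compound 1 to compound 2 (0.25 log units; within the scatter) lies within the scatter. Compound 3 `Cc1ccc(S(=O)(=O)NCc2cn(C[C@H](O)[C@H]3OC(=O)C(OCc4ccccc4)=C3OCc3ccccc3)nn2)cc1` differs from compound 2 by a group of 12 heavy atoms (8 carbon, 1 nitrogen, 2 oxygen, 1 sulfur; one six-membered aromatic ring of carbon only) in place of a group of 4 heavy atoms (3 carbon, 1 silicon; no ring), on an aromatic carbon. Among the measured compounds shown here, the only measured step, a 1.8-fold lower number from compound 1 to compound 2 (0.25 log units; within the scatter), is a small swap on an aromatic carbon of the shared core and changed nothing beyond the scatter, so it offers little guidance for a change of quite different kind and much larger size. For the measured compounds named here, with no comparable step available, the expected step in this assay, a 1.0-fold higher number from compound 2 to compound 3 (0.02 log units; within the scatter), amounts to no clear shift beyond the scatter, though with a wide range either way. Compound 3 is therefore estimated at 20000 nM in this assay, within 6000 nM to 70000 nM.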

Compound 3, half-maximal inhibitory concentration: 16800 nM
For compound 3 the middle estimate is 1.2-fold (0.08 log units) above the measured one; the measured number falls inside the stated range.
By their numbers in this assay, from the lowest: compounds 3, 2 and 1 (each within the scatter of the next, the first and the last beyond it).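

On an aromatic carbon of the shared core, the much larger (((4-methylphenyl)sulfonyl)amino)methyl, with its six-membered aromatic ring and hydrogen-bond donor, leaves the number in this assay within the scatter of the small silicon-bearing group (a 1.1-fold lower number from compound 2 to compound 3 (0.06 log units; within the scatter)). Against tert-butyl, the same group gives the first step among these compounds to lie beyond the scatter, though only modestly (a 2.0-fold lower number from compound 1 to compound 3 (0.31 log units; beyond the scatter)). Nothing at hand accounts for this result.

The compounds shown leave open which part of the entering group matters, since a plain aminomethyl group or a methylsulfonyl group in place of the 4-methylphenylsulfonyl part would separate its pieces. They also leave open how a carboxylic acid or a longer carbon chain at this position would read in this assay.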